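The compounds below may be only part of what the source reports. "The series", "measured", "known", "first", "only" and "open" are said of these compounds alone.

Compound 1, `C/C(=C\c1cc(-c2ccc(C)cc2)co1)C(N)=O`: in a functional assay on A549 cells (Homo sapiens) for cytotoxicity, read by CCK-8 assay, with a stated time of 24 h (a higher number here means a weaker inhibitor, a lower number a stronger inhibitor), compound 1 gives > 50000 nM, a limit of the assay.
Compound 2, `C/C(=C\c1cc(-c2ccccc2)cs1)C(N)=O`: in this assay compound 2 gives > 50000 nM, again a limit.
Compound 3, `C/C(=C\c1cc(-c2ccccc2C)cs1)C(N)=O`: in this assay compound 3 gives > 50000 nM, also a limit.

Compound 2 therefore stands at the limit of this assay, and so do both of its neighbours: the limit of > 50000 nM in this assay, at which 3 of the 3 values shown sit. Nothing among the numbers shown separates the three compounds from one another. Among the compounds with values here, the single step that can be traced between measured compounds, a step that the two limits leave unreadable from compound 2 to compound 3, is methyl in place of hydrogen on an aromatic carbon, and because both ends sit at the limit of > 50000 nM in this assay, at which 3 of the 3 values shown sit, its size cannot be read.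

Compound 4, `C/C(=C\c1cc(-c2ccc(S(C)(=O)=O)cc2)cs1)C(N)=O`, arises from compound 2 by methylsulfonyl in place of hydrogen on an aromatic carbon. Within the data shown here, the only measured step that bears on it, the one from compound 2 to compound 3, is unreadable, so no direction and no size can be carried over to this assay. The expectation for compound 4 is accordingly that the step that the limit leaves unreadable from compound 2 to compound 4 stays within the scatter and that the assay most likely again reports only a limit. On that basis compound 4 is estimated at 60000 nM, with a range from 20000 nM to 200000 nM.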

Compound 4, half-maximal inhibitory concentration: > 50000 nM
Compound 4 gave a limit, no number; the forecaster's own chance of this, stated with the estimate: 85%; the middle value is on the limit's open side.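

No new step can be read from compound 2 to compound 4, since both results in this assay are limits and the methylsulfonyl change has no readable size; the whole series stands the same way: the limit of > 50000 nM in this assay, at which 4 of the 4 values shown sit.

The compounds shown leave open whether any change to the shared core would give a measurable value in this assay.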